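The compounds below may be only part of what the source reports. "The series", "measured", "known", "first", "only" and "open" are said of these compounds alone.

Measured so far in a functional assay on A549 cells (Homo sapiens) for inhibition, read by MTT assay, with a stated time of 72 h; a higher number here means a weaker inhibitor, a lower number a stronger inhibitor:
- compound 1 `O=C(CCC(=O)OCCCCCCSc1ccc([N+](=O)[O-])c2nonc12)Nc1ccc(Br)cc1`: 3340 nM
- compound 2 `Cc1ccc(NC(=O)CCC(=O)OCCCCCCSc2ccc([N+](=O)[O-])c3nonc23)cc1`: 5240 nM

Compound 1 has the lowest of the two numbers in this assay, but its nearest neighbour, compound 2, sits only a 1.6-fold higher number from compound 1 to compound 2 (0.20 log units; within the scatter) away, a step that lies within the scatter, so the two cannot be placed in order. Compound 3 `O=C(CCC(=O)N1CCCCC1)OCCCCCCSc1ccc([N+](=O)[O-])c2nonc12` has not been measured. It differs from compound 1 by piperidin-1-yl in place of (4-bromophenyl)amino on a carbonyl carbon.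

Within the data shown here, none of the measured steps bears directly on this change. Among the measured compounds shown here, the single step available exchanges one substituent on the aromatic ring of the (4-bromophenyl)amino group, a ring that leaves entirely in compound 3, and that step stayed within the scatter. The change at the carbonyl carbon is therefore untested, and the expectation rests on compound 1 alone. Compound 3 is expected to give 4500 nM in this assay, with a range from 1500 nM to 14000 nM. For the measured compounds named here, this estimate means a step of a 1.3-fold higher number from compound 1 to compound 3 (0.13 log units; within the scatter), which is taken as no shift beyond the scatter, with a wide range because no measured step covers this position.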

Compound 3, half-maximal inhibitory concentration: 2510 nM
Estimate against measurement, compound 3: 1.8-fold (0.25 log units) above; the range from low to high includes it.
By their numbers in this assay, from the lowest: compounds 3, 1 and 2 (each within the scatter of the next, the first and the last beyond it).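

In this assay the step from (4-bromophenyl)amino to piperidin-1-yl on the carbonyl carbon is a 1.3-fold lower number from compound 1 to compound 3 (0.12 log units; within the scatter) and so shows that the aromatic ring and the hydrogen-bond donor of compound 1 can both leave without a shift that stands clear of the scatter. The same piperidin-1-yl in place of (4-methylphenyl)amino is a 2.1-fold lower number from compound 2 to compound 3 (0.32 log units; beyond the scatter) as a modest step, but this gives no firm ordering of the amino groups, since compound 1 and compound 2 remain within the scatter of each other and compound 1 and compound 3 do too. No measurement given here explains these numbers or connects them to any property of the groups.

Going by these compounds, whether this tolerance extends beyond piperidin-1-yl remains open, and a morpholin-4-yl ring, an open-chain diethylamino group or a free carboxylic acid on the same carbonyl carbon would test that more widely. On these data alone, it is also open whether a benzylamino group, which keeps an aromatic ring and the amide hydrogen but sets the ring further out, would stay within the same narrow band of values.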